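From bromo to ethoxycarbonyl on a shared core

The source may hold more compounds than are shown below. What is called first, only, known or untested is meant among the compounds shown, and "the series" means these compounds.

Compound 1 `OCc1ccc(NC(=S)Nc2ccc3[nH]ccc3c2)cc1`: 1080000 nM
Compound 2 `S=C(Nc1ccc(Br)cc1)Nc1ccc2[nH]ccc2c1`: 220000 nM

For the measured compounds named here, in an ADME assay on CHO-K1 cells (Cricetulus griseus) for cytotoxicity, read by MTT assay, with a stated time of 24 h (a lower number here means that less compound is tolerated, a higher number that more compound is tolerated), compound 2 gives 220000 nM, the lowest of the two numbers so far. Compound 3 `CCOC(=O)c1ccc(NC(=S)Nc2ccc3[nH]ccc3c2)cc1` replaces its bromo with ethoxycarbonyl on an aromatic carbon: ethoxycarbonyl in place of bromo on an aromatic carbon. Going by the values given here, only one measured step bears on this change, a 4.9-fold lower number from compound 1 to compound 2 (0.69 log units; beyond the scatter), which brought bromo in place of hydroxymethyl. Among the compounds with values here, with bromo leaving again, a modest rise in this assay is expected, probably no larger than that step, and the estimated change is a 1.8-fold higher number from compound 2 to compound 3 (0.26 log units; within the scatter). For compound 3 the expected value is 400000 nM, with an estimated range of 160000 nM to 1000000 nM.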

Compound 3, concentration lethal to 50% of the cells: 123000 nM
The estimate for compound 3 lay 3.3-fold (0.51 log units) above the measured number; measured number outside the range, below it.
By their numbers in this assay, from the lowest: compounds 3 and 2 (each within the scatter of the next); then compound 1.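

In this assay, ethoxycarbonyl does not bring back the higher number seen with hydroxymethyl: a 1.8-fold lower number from compound 2 to compound 3 (0.25 log units; within the scatter), so ethoxycarbonyl and bromo cannot be told apart at this position, whereas an 8.8-fold lower number from compound 1 to compound 3 (0.94 log units; beyond the scatter). Compound 1 therefore stands apart from the other two compounds, even though ethoxycarbonyl, with 5 heavy atoms and 2 hydrogen-bond acceptors, differs from bromo in size and acceptor count. Nothing available explains this result.

On these data alone, it remains open whether an amine or a carboxylic acid here would fall with hydroxymethyl or with bromo and ethoxycarbonyl.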